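A few compounds are considered here, and "the series" means these few. Any claim that something is new, unique, unknown or untested is made for them only; others in the source may bear on it.

Working notes on the aryl urea series.

Compound 1 `CN(C)CCCNc1nc(-c2ccc(NC(=O)Nc3ccccc3F)cc2)nc2ccsc12` and compound 2 `CN(C)CCCNc1nc(-c2ccc(NC(=O)Nc3ccccc3Cl)cc2)nc2ccsc12` share one core; compound 3 `CCN(CC)CCNc1nc(-c2ccc(NC(=O)Nc3ccc(F)cc3)cc2)nc2c(Cl)c(Cl)sc12` and compound 4 `CCN(CC)CCNc1nc(-c2ccc(NC(=O)Nc3ccc(Cl)cc3)cc2)nc2c(Cl)c(Cl)sc12` share another. The difference between the two cores is not broken down here. In a functional assay on NCI-H460 cells (Homo sapiens) for cytotoxicity, read by MTT assay, with a stated time of 72 h (on this read-out lower numbers stand for stronger inhibition and higher numbers for weaker inhibition), compound 1 gives 530 nM, compound 2 gives 430 nM and compound 3 gives 500 nM; all three numbers lie within the scatter of one another, so no order among them is claimed.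

The change from compound 1 to compound 2 is chloro in place of fluoro on an aromatic carbon and it made a step of a 1.2-fold lower number from compound 1 to compound 2 (0.09 log units; within the scatter) in this assay. The change from compound 3 to compound 4 is chloro in place of fluoro on an aromatic carbon. Both are the same kind of change, but the place differs: in the first the chloro sits ortho to a large group, in the second para to a large group, and the cores differ too.

For compound 4 in this assay a step of a 1.2-fold lower number from compound 3 to compound 4 (0.07 log units; within the scatter) is expected, resting on compound 1 to compound 2 giving a 1.2-fold lower number from compound 1 to compound 2 (0.09 log units; within the scatter). Compound 4 is therefore estimated at 430 nM, with a likely range from 250 nM to 750 nM.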

Compound 4, half-maximal inhibitory concentration: 320 nM
For compound 4 the middle estimate is 1.3-fold (0.13 log units) above the measured one, within the range that was stated.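

In this assay chloro in place of fluoro on the core of the dichlorinated pair gives a 1.6-fold lower number from compound 3 to compound 4 (0.19 log units; within the scatter), so this change does not move the number beyond the scatter on this core, just as it does not on the other. Set beside the earlier step, the new one does not stand apart from it: the same change on two cores in this assay, a 1.2-fold lower number (0.09 log units; within the scatter) from compound 1 to compound 2 and a 1.6-fold lower number (0.19 log units; within the scatter) from compound 3 to compound 4, 1.3-fold (0.10 log units) apart, within the scatter of two such steps. This fits the change carrying from one core to the other without a step that can be told from the scatter, but it does not show a real effect of the change that transfers, and with core and place differing together, the two steps cannot separate the one from the other.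

Still open, from the compounds shown here alone, is whether bromo, methoxy or nitrile in place of the chloro of the 4-chlorophenyl group would give a step beyond the scatter, and whether fluoro to chloro reads the same at one place on both cores. Also open, going by these compounds, is how a morpholine or a carboxylic acid at the end of the amine chain would read in this assay.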